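The compounds below may be only part of what the source reports. "The series", "measured", "known", "first", "only" and "open" are said of these compounds alone.

In an assay on isolated protein for displacement of a labelled ligand from melanin-concentrating hormone receptor 1 (Homo sapiens) (on this read-out higher numbers stand for weaker inhibition and lower numbers for stronger inhibition), the three compounds already measured span a wide stretch. Compound 1, `CCCc1cc(N)c2cc(NC(=O)c3ccc(-c4ccc(Cl)cc4)cc3)ccc2n1`, gives 0.7 nM. Compound 2, `CCCc1cc(N)c2cc(NC(=O)/C=C/c3ccc(F)cc3)ccc2n1`, gives 130 nM. Compound 3, `CCCc1cc(N)c2cc(NC(=O)CCc3ccccc3)ccc2n1`, gives 8300 nM. Compound 2 therefore holds the second highest of the three numbers: compound 3 sits beyond the scatter above it, and compound 1 sits beyond the scatter below it, so compound 2 is neither the strongest nor the weakest of the set.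

The next compound, compound 4, is `CCCc1cc(N)c2cc(NC(=O)/C=C/c3ccc(Cl)c(Cl)c3)ccc2n1`. It differs from compound 2 in one place: 3,4-dichlorophenyl in place of 4-fluorophenyl on a double-bonded chain carbon bound to a double-bonded chain carbon. The double-bonded chain and the amide are kept; only the aromatic ring at the end of the chain changes its halogen pattern.

Going by the values given here, no directly measured step of this kind is available among the three compounds, so the expectation rests on the neighbourhood of compound 2 in this assay. A modest step in the direction of a lower number is expected, a 3.3-fold lower number from compound 2 to compound 4 (0.51 log units; beyond the scatter), with compound 4 expected to come out near 40 nM, within a range from 8 nM to 200 nM.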

Compound 4, half-maximal inhibitory concentration: 60 nM
Estimate against measurement, compound 4: 1.5-fold (0.18 log units) below; the range from low to high includes it.
By their numbers in this assay, from the lowest: compound 1; then compound 4; then compound 2; then compound 3.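

In this assay, going by these compounds alone, the replacement of 4-fluorophenyl by 3,4-dichlorophenyl on a double-bonded chain carbon bound to a double-bonded chain carbon gives a 2.2-fold lower number from compound 2 to compound 4 (0.34 log units; beyond the scatter) as the only step so far between compounds that differ in one place. It shows that the number at this position answers to the halogen pattern on the ring, though only modestly, with the double-bonded chain and the amide kept. It also shows that this position accepts two chlorine atoms in place of one fluorine atom without any loss on this read-out.

The change alters both the kind and the count of halogen atoms, so the compounds shown do not separate the two, and they leave open what a single chlorine, a methoxy group or a dimethylamino group on this ring would give. No measurement at hand bears on why the number moved.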